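Three Azoles Measured, a Fourth Azole Expected

This account rests on a few compounds, and the source may have more. Where it says the series, first, only, none or still open, it means among the compounds named here.

Compound 1 `O=C(O)CC(c1ccc(OCC2COc3ccc(Cl)cc3O2)cc1)c1cnco1`: 63% in a functional assay on HEK293 cells for agonist activity at Free fatty acid receptor 1 (Homo sapiens), read by fluorescence and calcium flux, with a stated time of 10 min; a lower number here means a smaller maximal response, a higher number a larger maximal response
Compound 2 `Cn1ccnc1C(CC(=O)O)c1ccc(OCC2COc3ccc(Cl)cc3O2)cc1`: 68%
Compound 3 `Cn1nncc1C(CC(=O)O)c1ccc(OCC2COc3ccc(Cl)cc3O2)cc1`: 70%

Compound 3 sits within the scatter of both its neighbours: the step of a number 2 percentage points higher from compound 2 to compound 3 (within the scatter) and the step of a number 7 percentage points higher from compound 1 to compound 3 (within the scatter) are both small, so the three numbers read as a single level rather than a ranking. Compound 4 `Cn1cncc1C(CC(=O)O)c1ccc(OCC2COc3ccc(Cl)cc3O2)cc1` is the next variation on this shared core: 1-methyl-1H-imidazol-5-yl in place of 1-methyl-1H-1,2,3-triazol-5-yl on a saturated chain carbon bound to an aromatic carbon and a saturated chain carbon. Among the compounds with values here, the steps that bear on this change are a number 2 percentage points higher from compound 2 to compound 3 (within the scatter) and a number 5 percentage points higher from compound 1 to compound 2 (within the scatter), each an exchange of one five-membered aromatic ring for another and each within the scatter. A further exchange of that kind is therefore expected to give no step beyond the scatter in this assay. For compound 4 the expected step is a number 2 percentage points lower from compound 3 to compound 4 (within the scatter). Compound 4 is estimated at 68%, with a range from 58% to 78%.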

Compound 4, largest response reached (Emax), in percent of the reference or control that the assay uses: 62%
For compound 4 the middle estimate is 6 percentage points above the measured one; the range from low to high includes it.
By their numbers in this assay, from the lowest: compounds 4, 1, 2 and 3 (each within the scatter of the next).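

In this assay the place on a saturated chain carbon bound to an aromatic carbon and a saturated chain carbon now holds four five-membered aromatic rings at one level, since a number 8 percentage points lower from compound 3 to compound 4 (within the scatter) and a number 6 percentage points lower from compound 2 to compound 4 (within the scatter) and a number 1 percentage points lower from compound 1 to compound 4 (within the scatter) are all within the scatter. Even 1-methyl-1H-imidazol-5-yl in place of 1-methyl-1H-imidazol-2-yl, two attachments of one ring, gives no step beyond it. No available evidence explains this result. Still open, from the compounds shown here alone, is whether a phenyl ring, a pyridin-2-yl ring or a plain methyl group at this place would stay at that level.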